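From Fluoro to Trifluoromethyl on Compound 2

This account rests on a few compounds, and the source may have more. Where it says the series, first, only, none or still open, it means among the compounds named here.

In a functional assay on HeLa cells (Homo sapiens) for antiproliferative activity, read by MTT assay, with a stated time of 48 h (a lower number here means a stronger inhibitor, a higher number a weaker inhibitor), compound 1 `Fc1ccc2[nH]c(-c3cn(-c4ccccc4)nc3-c3ccc(Cl)cc3)nc2c1` gives 2770 nM and compound 2 `COc1ccc(-c2nn(-c3ccccc3)cc2-c2nc3cc(F)ccc3[nH]2)cc1` gives 1740 nM and thus stands level with compound 1 within the scatter. Compound 3 `COc1ccc(-c2nn(-c3ccccc3)cc2-c2nc3cc(C(F)(F)F)ccc3[nH]2)cc1` differs from compound 2 by trifluoromethyl in place of fluoro on an aromatic carbon. Within the data shown here, the one measured step (a 1.6-fold lower number from compound 1 to compound 2 (0.20 log units; within the scatter)) lies within the scatter and involves a different change, so it sets no direction here. The step expected in this assay therefore stays within the scatter, with no firm direction (a 1.2-fold lower number from compound 2 to compound 3 (0.06 log units; within the scatter) is the estimate). Compound 3 is expected at 1500 nM (range 500 nM to 4500 nM).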

Compound 3, half-maximal inhibitory concentration: 2760 nM
Compound 3: middle estimate off by 1.8-fold (0.26 log units), on the low side; low and high end bracket the measured number.
By their numbers in this assay, from the lowest: compounds 2, 3 and 1 (each within the scatter of the next).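

In this assay replacing fluoro with trifluoromethyl on this aromatic carbon gives a 1.6-fold higher number from compound 2 to compound 3 (0.20 log units; within the scatter) and so shows no firm effect of the change, even though the entering group has more heavy atoms. Among these compounds, this is the first look at this position, as the earlier step changed only chloro to methoxy at another site. Nothing available accounts for this result.

As far as these compounds go, whether an amine or a carboxylic acid at this position would move the number beyond the scatter stays open. So does whether the trifluoromethyl result would hold with chloro in place of methoxy.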